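Swapping the benzamide aryl group in a weak antiproliferative series

The source may hold more compounds than are shown below. What is called first, only, known or untested is meant among the compounds shown, and "the series" means these compounds.

Of the compounds shown here, two on a shared core have been measured. Compound 1 `O=C(Nc1cccc(-c2oc3cc(-c4ccc(F)cc4)ccc3c(=O)c2O)c1)c1ccc(C(F)(F)F)cc1` gives 17400 nM in a functional assay on HeLa cells (Homo sapiens) for antiproliferative activity, read by CCK-8 assay, with a stated time of 72 h; on this read-out lower numbers stand for stronger inhibition and higher numbers for weaker inhibition. Compound 2 `Cc1cc(C(=O)Nc2cccc(-c3oc4cc(-c5ccc(F)cc5)ccc4c(=O)c3O)c2)ccc1F` gives 18900 nM in the same assay, and it stands with the highest of the two numbers, though its nearest neighbour, compound 1, sits within the scatter of it. Among the compounds with values here, the only measured step, a 1.1-fold higher number from compound 1 to compound 2 (0.04 log units; within the scatter), changes the aryl group on the carbonyl carbon and leaves the read-out essentially unchanged.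

Compound 3 `O=C(Nc1cccc(-c2oc3cc(-c4ccc(F)cc4)ccc3c(=O)c2O)c1)c1ccc([N+](=O)[O-])cc1` continues along this line: 4-nitrophenyl in place of 4-fluoro-3-methylphenyl on a carbonyl carbon. Within the data shown here, because the one step that bears on this position, a 1.1-fold higher number from compound 1 to compound 2 (0.04 log units; within the scatter), stayed within the scatter, the same kind of change is expected to do little here as well. Compound 3 is therefore expected to give 18000 nM, with a plausible range from 7000 nM to 45000 nM. The expected step from compound 2 to compound 3 is a 1.1-fold lower number from compound 2 to compound 3 (0.02 log units; within the scatter), which amounts to no change beyond the scatter; the range is kept wide, since a single comparison gives little basis for predicting a new aryl group.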

Compound 3, half-maximal inhibitory concentration: 12300 nM
Compound 3: middle estimate off by 1.5-fold (0.17 log units), on the high side; low and high end bracket the measured number.
By their numbers in this assay, from the lowest: compounds 3, 1 and 2 (each within the scatter of the next).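

With 4-nitrophenyl, the position on the carbonyl carbon now holds a third aryl group, and in this assay the comparison still gives no separation: the readings are a 1.5-fold lower number from compound 2 to compound 3 (0.19 log units; within the scatter) and a 1.4-fold lower number from compound 1 to compound 3 (0.15 log units; within the scatter), so neither step lies beyond the scatter. This holds for the swap of the whole aryl group, where 4-nitrophenyl with its 2 hydrogen-bond acceptors enters for 4-fluoro-3-methylphenyl with none, and for the narrower swap of nitro for trifluoromethyl on an aromatic carbon, so compounds 1, 2 and 3 cannot be told apart in this assay. No supporting evidence is available to explain this result. As far as these compounds go, what remains open is whether an amine or a carboxylic acid on this phenyl ring, or a cyclohexyl group in place of the ring on the carbonyl carbon, would move the number beyond the scatter. From the compounds shown here alone, it is also open whether any change at this position can do so, or whether only changes elsewhere on the shared core, such as replacing the 4-fluorophenyl group with a morpholine, would separate compounds.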